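Hydroxy in Place of Fluoro on a Difluorinated Ring

This account rests on a few compounds, and the source may have more. Where it says the series, first, only, none or still open, it means among the compounds named here.

Compound 1 `C=CC[C@H]1C[C@]2([C@@H](C)Cc3ccc(OC)c(F)c3)OCOC2=CC1=O`, compound 2 `C=CC[C@H]1C[C@]2([C@@H](C)Cc3ccc(OC)c(O)c3)OCOC2=CC1=O` and compound 3 `C=CC[C@H]1C[C@]2([C@@H](C)Cc3cc(F)c(OC)cc3F)OCOC2=CC1=O` share one core and differ only on the aromatic ring. In a functional assay on NCI-H460 cells (Homo sapiens) for antiproliferative activity, with a stated time of 72 h (a higher number here means a weaker inhibitor, a lower number a stronger inhibitor), compound 1 gives 90 nM, compound 2 gives 80 nM and compound 3 gives 59 nM. The change from compound 1 to compound 2 is hydroxy in place of fluoro on an aromatic carbon and it gave a 1.1-fold lower number from compound 1 to compound 2 (0.05 log units; within the scatter). Compound 3 differs from compound 1 by fluoro in place of hydrogen on an aromatic carbon, with a 1.5-fold lower number from compound 1 to compound 3 (0.18 log units; within the scatter). Compound 4 `C=CC[C@H]1C[C@]2([C@@H](C)Cc3cc(O)c(OC)cc3F)OCOC2=CC1=O` is unmeasured; it differs from compound 3 by hydroxy in place of fluoro on an aromatic carbon. This is the same kind of change as that from compound 1 to compound 2, but here the place is also para to a fluoro group. For compound 4 a step of a 1.1-fold lower number from compound 3 to compound 4 (0.03 log units; within the scatter) is expected in this assay, because the same kind of change earlier gave a 1.1-fold lower number from compound 1 to compound 2 (0.05 log units; within the scatter). Compound 4 is therefore estimated at 55 nM, between 25 nM and 120 nM.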

Compound 4, half-maximal inhibitory concentration: 33 nM
Beside the measured number, compound 4's estimate is 1.7-fold (0.22 log units) above it; low and high end bracket the measured number.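

In this assay, hydroxy in place of fluoro on an aromatic carbon gave a 1.8-fold lower number from compound 3 to compound 4 (0.25 log units; within the scatter), and this step agrees with the one seen on the other core: the same change on two cores in this assay, a 1.1-fold lower number (0.05 log units; within the scatter) from compound 1 to compound 2 and a 1.8-fold lower number (0.25 log units; within the scatter) from compound 3 to compound 4, 1.6-fold (0.20 log units) apart, within the scatter of two such steps. Fluoro in place of hydrogen on an aromatic carbon gave a 2.4-fold lower number from compound 2 to compound 4 (0.38 log units; beyond the scatter), which also agrees with its earlier counterpart: the same change on two cores in this assay, a 1.5-fold lower number (0.18 log units; within the scatter) from compound 1 to compound 3 and a 2.4-fold lower number (0.38 log units; beyond the scatter) from compound 2 to compound 4, 1.6-fold (0.20 log units) apart, within the scatter of two such steps. Among these compounds, both changes therefore carried over between these two cores, but this rests on a single pair of steps for each change, and only the step from compound 2 to compound 4 lies beyond the scatter, so it shows neither a firm size for either change nor that either would carry to other cores.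

The compounds shown leave open how an amine or a carboxylic acid in the place of the hydroxy would behave in this assay. They also leave open whether these steps would hold with a longer chain in place of the methoxy group.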